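Replacing isopropyl with 2-fluorophenyl on the carbonyl

The source may report more compounds than this note shows. Statements on the series, on what has been measured and on what is new or still open speak of the compounds shown alone.

Compound 1 `COc1cc(/C=C2\CNC/C(=C\c3cc(OC)c(OC)c(OC)c3)C2=O)cc(OC)c1OC`: 1200 nM
Compound 2 `COc1cc(/C=C2\CN(C)C/C(=C\c3cc(OC)c(OC)c(OC)c3)C2=O)cc(OC)c1OC`: 1700 nM
Compound 3 `COc1cc(/C=C2\CN(C(=O)C(C)C)C/C(=C\c3cc(OC)c(OC)c(OC)c3)C2=O)cc(OC)c1OC`: 800 nM

In a functional assay on A549 cells (Homo sapiens) for cytotoxicity, read by MTT assay, with a stated time of 72 h (a higher number here means a weaker inhibitor, a lower number a stronger inhibitor), compound 3 gives 800 nM. That value stands within the scatter of compound 1 and modestly clear of compound 2 only. The next compound, compound 4 `COc1cc(/C=C2\CN(C(=O)c3ccccc3F)C/C(=C\c3cc(OC)c(OC)c(OC)c3)C2=O)cc(OC)c1OC`, keeps the shared core and changes one group: 2-fluorophenyl in place of isopropyl on a carbonyl carbon. This places 2-fluorophenyl in place of isopropyl on a carbonyl carbon, whose other neighbour is an amide-type nitrogen in a ring.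

Among the compounds with values here, no measured compound carries a ring on that carbonyl, so the evidence is indirect. Changes on the ring nitrogen have moved the number little so far: a 1.4-fold higher number from compound 1 to compound 2 (0.15 log units; within the scatter), a 1.5-fold lower number from compound 1 to compound 3 (0.18 log units; within the scatter) and a 2.1-fold lower number from compound 2 to compound 3 (0.33 log units; beyond the scatter). Only the last lies beyond the scatter, and only just. Compound 4 is therefore expected to stay close to compound 3, with no clear direction. The estimate amounts to a 1.1-fold lower number from compound 3 to compound 4 (0.06 log units; within the scatter), an expected step within the scatter. Compound 4 is estimated at 700 nM, with an expected range from 300 nM to 1600 nM.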

Compound 4, half-maximal inhibitory concentration: 700 nM
The estimate for compound 4 equals the measured number at the digits printed; the range from low to high includes it.
By their numbers in this assay, from the lowest: compounds 4, 3, 1 and 2 (each within the scatter of the next, the first and the last beyond it).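

On the carbonyl carbon whose other neighbour is an amide-type nitrogen in a ring, exchanging isopropyl, which has no ring, for 2-fluorophenyl, with its six-membered aromatic ring, gives a 1.1-fold lower number from compound 3 to compound 4 (0.06 log units; within the scatter) in this assay, so this larger group leaves the number where it was. Set against the smaller groups on the ring nitrogen, (2-fluorophenyl)carbonyl gives a 2.4-fold lower number from compound 2 to compound 4 (0.39 log units; beyond the scatter) from methyl and a 1.7-fold lower number from compound 1 to compound 4 (0.23 log units; within the scatter) from hydrogen, which matches the earlier picture for isopropylcarbonyl: only the comparison with compound 2 lies beyond the scatter. Nothing measured here accounts for these small steps.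

Going by these compounds, what the fluorine itself contributes stays open, and a plain phenyl on that carbonyl would be the comparison to settle it. Also open, on these data alone, is whether a longer chain or a ring bearing an amine at this carbonyl would shift the number beyond the scatter.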